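Compound 3 to compound 4: a new group on nitrogen

This account rests on a few compounds, and the source may have more. Where it says the series, first, only, none or still open, it means among the compounds named here.

Compound 1 `CCCCn1nc(C(=O)N[C@H]2COc3ccccc3N(C)C2=S)nc1Cc1ccccc1` gives 510 nM
Compound 2 `CC(C)n1nc(C(=O)N[C@H]2COc3ccccc3N(C)C2=S)nc1Cc1ccccc1` gives 360 nM
Compound 3 `CN1C(=S)[C@@H](NC(=O)c2nc(Cc3ccccc3)n(CC3CCOC3)n2)COc2ccccc21` gives 4420 nM

In a functional assay on HT-29 cells (Homo sapiens) for inhibition, read by luminescence and CellTiter-Glo, with a stated time of 24 h (on this read-out higher numbers stand for an effect only at larger amounts of compound and lower numbers for an effect already at smaller amounts), compound 3 has the highest number of the three. The gaps to the other two are beyond the scatter, with an 8.7-fold higher number from compound 1 to compound 3 (0.94 log units; beyond the scatter) and a 12-fold higher number from compound 2 to compound 3 (1.09 log units; beyond the scatter) as the two steps that set it apart. The other two do not separate, as a 1.4-fold lower number from compound 1 to compound 2 (0.15 log units; within the scatter) shows.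

Compound 4 `Cc1cnc(-n2nc(C(=O)N[C@H]3COc4ccccc4N(C)C3=S)nc2Cc2ccccc2)nc1` keeps the shared core and the benzyl group and differs from compound 3 only in the group on the aromatic nitrogen, as 5-methylpyrimidin-2-yl in place of (oxolan-3-yl)methyl on an aromatic nitrogen sets out. The group that enters holds a six-membered aromatic ring, and the one that leaves holds a five-membered non-aromatic ring.

Among the measured compounds shown here, no compound measured so far has an aromatic ring on that nitrogen, so the three steps bear on the change only indirectly. They show that the group at this place can move the number substantially. Since compound 3 sits at the high end and both other groups gave lower numbers, a modest step to a lower number is expected in this assay, though with little certainty. The step estimated on this reasoning is a 4.4-fold lower number from compound 3 to compound 4 (0.65 log units; beyond the scatter). For compound 4 the expected value is 1000 nM, with an estimated range from 200 nM to 5000 nM.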

Compound 4, half-maximal effective concentration: 1950 nM
For compound 4 the middle estimate is 2.0-fold (0.29 log units) below the measured one; the range from low to high includes it.
By their numbers in this assay, from the lowest: compounds 2 and 1 (each within the scatter of the next); then compound 4; then compound 3.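

With 5-methylpyrimidin-2-yl, the first aromatic ring on this nitrogen, this assay shows a 2.3-fold lower number from compound 3 to compound 4 (0.36 log units; beyond the scatter), so an aromatic ring here does not give the highest number of the four compounds; that place stays with (oxolan-3-yl)methyl. The same ring does not match either open-chain group, with a 5.4-fold higher number from compound 2 to compound 4 (0.73 log units; beyond the scatter) against isopropyl and a 3.8-fold higher number from compound 1 to compound 4 (0.58 log units; beyond the scatter) against butyl, so the new group falls between the two chains and the oxolane-bearing group. Across these four compounds, then, both groups that hold a ring stand at higher numbers than both chains, with no compound going against this, although only two ring-bearing groups are shown and no data shown here give a reason for these differences.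

Going by these compounds, what a plain phenyl ring would give at this place remains open, as does whether the methyl group on the pyrimidine ring contributes to the number. On these data alone, it is also open how a chain carrying an amine or a carboxylic acid would compare with butyl and isopropyl.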